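From Propyl to Piperazin-1-yl on a Shared Core

The source may hold more compounds than are shown below. What is called first, only, known or untested is meant among the compounds shown, and "the series" means these compounds.

Within the data shown here, only two compounds have been measured so far in a functional assay on A549 cells (Homo sapiens) for cytotoxicity, read by sulforhodamine B assay; a lower number here means a stronger inhibitor, a higher number a weaker inhibitor. In this test, compound 1 `CCCCN1C(=O)c2cccc3c2c(cc2c4ccccc4sc32)C1=O` gives 1350 nM, and compound 2 `CCCCN1C(=O)c2cccc3c2c(cc2c4ccccc4oc32)C1=O` gives 1400 nM. These two values lie within the usual scatter of repeated measurements, so compound 2 stands level with compound 1 on the available numbers.

The next compound, compound 3 `O=C1c2cccc3c2c(cc2c4ccccc4oc32)C(=O)N1CN1CCNCC1`, keeps the core of compound 2 but changes its side chain. It carries piperazin-1-yl in place of propyl on a saturated chain carbon bound to an amide-type nitrogen in a ring. Among the measured compounds shown here, no measured pair here shows what a change of this kind does, so any forecast must stay loose. In this assay, a modest step toward a lower number is expected, although a step the other way remains possible. The estimated change is a 1.6-fold lower number from compound 2 to compound 3 (0.19 log units; within the scatter). In this assay, compound 3 is expected at 900 nM, with an estimated range from 200 nM to 4000 nM.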

Compound 3, half-maximal inhibitory concentration: > 100000 nM
Compound 3 ended at the assay's limit; the forecaster's own chance of this, stated with the estimate: 10%; middle value at least 110-fold (2.04 log units) away from the limit.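

At the position named by the new step, a saturated chain carbon bound to an amide-type nitrogen in a ring, replacing propyl with piperazin-1-yl gives an at least 71-fold higher number from compound 2 to compound 3 (1.85 log units; beyond the scatter) in this assay. Among these compounds, this is the first change here that moves the reading beyond the scatter, as compounds 1 and 2 carry the same side chain and so could not show what a change at this position does. The reading for compound 3 is a limit of the assay, not a number, and it shows that on this core the group at this position can decide the outcome, at least for this one swap: the limit of > 100000 nM in this assay, at which 1 of the 3 values shown sits.

This single pair changes several things at once, since the entering group brings a non-aromatic ring, nitrogen atoms and a hydrogen-bond donor together, so it cannot tell which of them goes with the result, and no cause can be given. On these data alone, whether a morpholin-4-yl ring or a simple dimethylamino group at the same place would read like propyl or like piperazin-1-yl remains open.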